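Amino acid amides: from the aspartate to the longer diacid

This account rests on a few compounds, and the source may have more. Where it says the series, first, only, none or still open, it means among the compounds named here.

Measured in a functional assay on BXPC-3 cells (Homo sapiens) for antiproliferative activity, read by MTT assay, with a stated time of 24 h; on this read-out higher numbers stand for weaker inhibition and lower numbers for stronger inhibition:
compound 1 `CCn1c(C(=O)NCC(=O)O)ccc1C(CC)(CC)c1ccc(OCS(=O)(=O)c2ccccc2)c(C)c1` gives > 50000 nM
compound 2 `CCn1c(C(=O)N[C@@H](C(=O)O)C(C)C)ccc1C(CC)(CC)c1ccc(OCS(=O)(=O)c2ccccc2)c(C)c1` gives 13900 nM
compound 3 `CCn1c(C(=O)N[C@H](CC(=O)O)C(=O)O)ccc1C(CC)(CC)c1ccc(OCS(=O)(=O)c2ccccc2)c(C)c1` gives > 50000 nM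

Compound 3 stands at > 50000 nM, which is a limit and not a number. Compound 1 gives > 50000 nM, also a limit. These two make up (the limit of > 50000 nM in this assay, at which 2 of the 3 values shown sit), and compound 2 alone has a measured number.

Compound 4 `CCn1c(C(=O)N[C@@H](CCC(=O)O)C(=O)O)ccc1C(CC)(CC)c1ccc(OCS(=O)(=O)c2ccccc2)c(C)c1` carries 1,3-dicarboxypropyl in place of 1,2-dicarboxyethyl on an amide-type nitrogen.

For the measured compounds named here, no measured step makes this exact change. The nearest evidence is an at least 3.5-fold lower number from compound 1 to compound 2 (0.55 log units; beyond the scatter) with isopropyl in place of hydrogen, and an at least 3.5-fold higher number from compound 2 to compound 3 (0.55 log units; beyond the scatter) with carboxymethyl in place of isopropyl. Both are at least modest, and the second runs back up to the limit. The remaining step, a step that the two limits leave unreadable from compound 1 to compound 3, cannot be sized.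

The side chain of compound 4 stays a dicarboxy chain, so it resembles compound 3 at > 50000 nM far more than the isopropyl of compound 2 at 13900 nM. The expected result in this assay is no step beyond the scatter, estimated as a number no higher from compound 3 to compound 4 (the limit leaves the size open), and a second limit is the likeliest outcome. The estimated value for compound 4 is 50000 nM, with an expected range from 22000 nM to 90000 nM.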

Compound 4, half-maximal inhibitory concentration: > 50000 nM
Compound 4: only a limit was reported (the forecaster's own chance of this, stated with the estimate: 65%); the middle value lies on the limit itself.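

In this assay compound 4 gives > 50000 nM, which is a limit and not a number, so the longer 1,3-dicarboxypropyl on the amide-type nitrogen leaves the series at the same limit as 1,2-dicarboxyethyl. Set against the 1-carboxy-2-methylpropyl of the only amide with a measured number, this chain gives an at least 3.5-fold higher number from compound 2 to compound 4 (0.55 log units; beyond the scatter), so a second dicarboxy chain now stands on the same side of compound 2 as compound 3, although compound 1, with no second carboxyl, stands there too. The steps from compound 3 to compound 4 and from compound 1 to compound 4 cannot be read, and the series now gathers at one ceiling: the limit of > 50000 nM in this assay, at which 3 of the 4 values shown sit.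

Going by these compounds, how far compound 1, compound 3 and compound 4 lie from one another remains unknown, and so does whether the added methylene has any effect at all. Also open, on these data alone, is whether a longer hydrocarbon side chain such as isobutyl or benzyl would carry the series further from the limit than the isopropyl of compound 2, and whether an amine or a primary amide at the end of the chain, in place of the second carboxylic acid, would bring it off the limit.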